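Cyclobutyl for cyclopropylmethyl on the amine nitrogen

The source may report more compounds than this note shows. Statements on the series, on what has been measured and on what is new or still open speak of the compounds shown alone.

In a physicochemical assay for solubility, at pH 1.1 (on this read-out lower numbers stand for lower solubility and higher numbers for higher solubility), compound 1 `CCN(Cc1ccc(OCCn2c(=O)ccn(C)c2=O)c(C)c1)C(CC(=O)O)c1ccc(Cl)cc1` gives 3000000 nM. Compound 2 `CCCN(Cc1ccc(OCCn2c(=O)ccn(C)c2=O)c(C)c1)C(CC(=O)O)c1ccc(Cl)cc1` gives 3000000 nM. Compound 3 `Cc1cc(CN(CC2CC2)C(CC(=O)O)c2ccc(Cl)cc2)ccc1OCCn1c(=O)ccn(C)c1=O` gives 3000000 nM, level with the other two at the digits shown.

The next structure is compound 4 `Cc1cc(CN(C2CCC2)C(CC(=O)O)c2ccc(Cl)cc2)ccc1OCCn1c(=O)ccn(C)c1=O`. It carries cyclobutyl in place of cyclopropylmethyl on an amine nitrogen, and the two compounds have the same atoms, joined differently.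

Three measured steps change the group at this nitrogen: no change at the digits printed from compound 1 to compound 2 (within the scatter), no change at the digits printed from compound 1 to compound 3 (within the scatter) and no change at the digits printed from compound 2 to compound 3 (within the scatter). None of them moves this assay beyond the scatter. For the measured compounds named here, no measured compound carries cyclobutyl on this nitrogen, so the expectation rests on these three steps alone. No change beyond the scatter is therefore expected in this assay.

The expected step is no change at the digits printed from compound 3 to compound 4 (within the scatter).

For compound 4 the estimated value is 3000000 nM, with an expected range of 1500000 nM to 4000000 nM.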

Compound 4, solubility: 3000000 nM
For compound 4 middle estimate and measured number coincide at the digits printed, within the range that was stated.
By their numbers in this assay, from the lowest: compounds 1, 2, 3 and 4 (each within the scatter of the next).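

In this assay a four-membered ring of carbon only now sits on this amine nitrogen, and cyclobutyl in place of cyclopropylmethyl, with the heavy-atom count unchanged, gives no change at the digits printed from compound 3 to compound 4 (within the scatter) in the read-out. Against the open chains, the same ring gives no change at the digits printed from compound 2 to compound 4 (within the scatter) for propyl and no change at the digits printed from compound 1 to compound 4 (within the scatter) for ethyl, so all four compounds, ring-bearing or open-chain, stand level at the digits printed, with none going against this. Nothing measured here offers a reason for this level read-out.

On these data alone, whether a hydroxyethyl or a cyclohexyl group on this nitrogen would move this assay remains open. Also open, as far as these compounds go, is whether the same level holds when an amide takes the place of the carboxylic acid of the shared core.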